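Selenium-chain shortening on two cores in a CCRF-CEM cytotoxicity test

The compounds below may be only part of what the source reports. "The series", "measured", "known", "first", "only" and "open" are said of these compounds alone.

The study compares two cores that carry a pentyl chain on selenium and asks what a methyl chain does in their place. Compound 1 `CCCCC[Se]c1nc(NCc2ccccc2)c2ccccc2n1` and compound 3 `C[Se]c1nc(NCc2ccccc2)c2ccccc2n1` share one core; compound 2 `CCCCC[Se]c1nc(N)c2cccnc2n1` and compound 4 `C[Se]c1nc(N)c2cccnc2n1` share the other, and the difference between the two cores is not broken down here. In a functional assay on CCRF-CEM cells (Homo sapiens) for cytotoxicity, read by MTT assay, with a stated time of 72 h (on this read-out higher numbers stand for lower toxicity in this test and lower numbers for higher toxicity in this test), compound 1 gives only a limit of the test, > 100000 nM, which is the line (the limit of > 100000 nM in this assay, at which 1 of the 3 values shown sits). In this assay compound 3 gives 83500 nM, and compound 2 gives 72600 nM. The measured change hydrogen in place of butyl on a saturated chain carbon bound to a selenium atom produced an at least 1.1-fold lower number from compound 1 to compound 3 (0.07 log units; that floor lies within the scatter). The same change is now made on the second core as hydrogen in place of butyl on a saturated chain carbon bound to a selenium atom. For compound 4 the author expects a 1.2-fold lower number from compound 2 to compound 4 (0.08 log units; within the scatter), a step of about the same small size, resting on the step from compound 1 to compound 3 and on compound 2 at 72600 nM. The estimate for compound 4 in this assay is therefore 60000 nM, with a range from 25000 nM to 150000 nM.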

Compound 4, concentration lethal to 50% of the cells: > 100000 nM
Compound 4 was reported as a limit (the forecaster's own chance of this, stated with the estimate: 15%); at least 1.6-fold (0.22 log units) between middle value and limit.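

In this assay the change from pentyl to methyl on the second core gives an at least 1.3-fold higher number from compound 2 to compound 4 (0.13 log units; that floor lies within the scatter). Compound 4 stands only as a limit of the test, > 100000 nM. Set beside the step on the first core, this result shows neither that the change carries over unchanged from one core to the other nor that it acts differently on the two: the same change on two cores in this assay, an at least 1.1-fold lower number (0.07 log units; that floor lies within the scatter) from compound 1 to compound 3 and an at least 1.3-fold higher number (0.13 log units; that floor lies within the scatter) from compound 2 to compound 4; the limit leaves it open whether they differ

The compounds shown leave open how the number would respond to a chain of intermediate length on selenium, such as propyl, or to a chain ending in an amine or a carboxylic acid, on either core. The true size of both steps also stays open, as each of them has a limit at one end: the limit of > 100000 nM in this assay, at which 2 of the 4 values shown sit.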